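The source may hold more compounds than are shown below. What is called first, only, known or untested is meant among the compounds shown, and "the series" means these compounds.

In a functional assay on SK-BR-3 cells (Homo sapiens) for antiproliferative activity (a lower number here means a stronger inhibitor, a higher number a weaker inhibitor), compound 3 `CCCCCC(=O)Nc1cc2ccc(O[C@@H]3OC(C)(C)[C@H](OC)[C@@H](O)[C@H]3O)c(C)c2oc1=O` gives 84000 nM, the lowest number among the measured compounds. Compound 1 `CCC(=O)Nc1cc2ccc(O[C@@H]3OC(C)(C)[C@H](OC)[C@@H](O)[C@H]3O)c(C)c2oc1=O` gives 643000 nM. Compound 2 `CO[C@@H]1[C@@H](O)[C@@H](O)[C@H](Oc2ccc3cc(NC(C)=O)c(=O)oc3c2C)OC1(C)C` reads > 900000 nM, which is a limit of the assay and not a number. The steps toward compound 3 are clear: a 7.7-fold lower number from compound 1 to compound 3 (0.88 log units; beyond the scatter) is a modest step and an at least 10-fold lower number from compound 2 to compound 3 (1.02 log units; beyond the scatter) a large one, whereas an at least 1.3-fold higher number from compound 1 to compound 2 (0.14 log units; that floor lies within the scatter) stays within the scatter.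

Compound 4 `CO[C@@H]1[C@@H](O)[C@@H](O)[C@H](Oc2ccc3cc(NC(=O)C4CCC4)c(=O)oc3c2C)OC1(C)C` brings a different kind of change, (cyclobutyl in place of pentyl on a carbonyl carbon), with cyclobutyl in place of pentyl on a carbonyl carbon. Among the measured compounds shown here, no measured compound carries a ring at this place, so the chain steps are the only guide. With the pentyl chain gone, compound 4 is expected to give back part of the gain seen in a 7.7-fold lower number from compound 1 to compound 3 (0.88 log units; beyond the scatter). In this assay, the expected move is a modest one toward a higher number, estimated as a 3.6-fold higher number from compound 3 to compound 4 (0.55 log units; beyond the scatter). For compound 4 the estimated value is 300000 nM, with an expected range of 100000 nM to 850000 nM.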

Compound 4, half-maximal inhibitory concentration: 220000 nM
Compound 4: middle estimate off by 1.4-fold (0.13 log units), on the high side; measured number inside the range.
By their numbers in this assay, from the lowest: compound 3; then compound 4; then compound 1. At a limit, above all of these: compound 2.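

The earlier compounds shown here carried only open chains on the carbonyl carbon, and compound 4 shows that a ring at this place gives a reading that lies among theirs in this assay. Cyclobutyl keeps part of the gain that pentyl brought, with a 2.9-fold lower number from compound 1 to compound 4 (0.47 log units; beyond the scatter), but does not match pentyl, with a 2.6-fold higher number from compound 3 to compound 4 (0.42 log units; beyond the scatter). Compound 2 reads a limit and not a number, so an at least 4.0-fold lower number from compound 2 to compound 4 (0.61 log units; beyond the scatter) is only a floor: the limit of > 900000 nM in this assay, at which 1 of the 4 values shown sits.

The compounds shown leave open whether an open butyl chain on the carbonyl carbon would read like cyclobutyl, so the effect of the ring cannot yet be separated from that of the carbon count. They also leave open what a longer chain such as heptyl, or a larger ring such as cyclohexyl or phenyl, would give at this place.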